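Hydroxy on the acetamido terminus of compound 3

The source may hold more compounds than are shown below. What is called first, only, known or untested is meant among the compounds shown, and "the series" means these compounds.

Measured so far:
compound 1, `C#CCNC1CCc2c(NCc3ccccc3)cccc21`: > 20000 nM
compound 2, `C#CCNC1CCc2c(SCc3ccc(Cl)cc3)cccc21`: 180 nM
compound 3, `C#CCNC1CCc2c(OCCc3cc(NC(C)=O)ccc3Cl)cccc21`: 590 nM

Compound 1 gives only a limit in an assay on cells for inhibition of Amine oxidase [flavin-containing] B (Homo sapiens), read by fluorescence and Amplex Red, with stated times of 30 min and 15 min (a higher number here means a weaker inhibitor, a lower number a stronger inhibitor), > 20000 nM, and that limit is recorded as the limit of > 20000 nM in this assay, at which 1 of the 3 values shown sits. Among the two numbers that are not limits, compound 3 stands highest in this assay with 590 nM, while compound 2 gives the lower number, 180 nM, a gap that lies beyond the scatter. Going by the values given here, no pair of measured compounds differs in one place only, so no measured step is available to lean on.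

Compound 4, `C#CCNC1CCc2c(OCCc3cc(NC(=O)CO)ccc3Cl)cccc21`, is the next compound to be measured. It differs from compound 3 by hydroxy in place of hydrogen on a saturated chain carbon bound to a carbonyl carbon; the same change, cut one bond further out, reads acetamido to ((hydroxymethyl)carbonyl)amino. The change sits at the far end of the chain on the aryl ether, away from the propargylamine that compounds 1 to 3 share. With no measured step of this kind in the series, a change of this size is expected to move the number little, in either direction, and likely not beyond the scatter. Compound 4 is therefore estimated at 700 nM, within 250 nM to 2000 nM, which is expected to mean a step of a 1.2-fold higher number from compound 3 to compound 4 (0.07 log units; within the scatter).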

Compound 4, half-maximal inhibitory concentration: 270 nM
The estimate for compound 4 lay 2.6-fold (0.41 log units) above the measured number; the measured number falls inside the stated range.
By their numbers in this assay, from the lowest: compounds 2 and 4 (each within the scatter of the next); then compound 3. At a limit, above all of these: compound 1.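

In this assay, going by these compounds alone, hydroxy in place of hydrogen on a saturated chain carbon bound to a carbonyl carbon gives a 2.2-fold lower number from compound 3 to compound 4 (0.34 log units; beyond the scatter), the first step that can be read between two compounds differing in one place. The far end of the chain on the aryl ether is therefore not a silent position: a change of 1 heavy atom, 1 oxygen, this far from the propargylamine moves the number beyond the scatter, though the step is modest, and it moves towards the stronger inhibitor. What lies behind the step is not settled by any measurement given here.

From the compounds shown here alone, with a single step at this position, it remains open whether the gain belongs to the hydroxy itself or would also come with another group on the same carbon, such as a methoxy, an amine or a carboxylic acid, or with a longer chain such as hydroxyethyl in place of hydroxymethyl. Also open, going by these compounds, is whether the same change would give a step of similar size on a compound with a different linker, such as compound 2.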